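The source may hold more compounds than are shown below. What is called first, only, known or untested is meant among the compounds shown, and "the series" means these compounds.

The measured compounds and their values in an assay on isolated protein for inhibition of lysosomal alpha-glucosidase (Homo sapiens); a higher number here means a weaker inhibitor, a lower number a stronger inhibitor:
compound 1, `CS/C(=C/C(=O)c1ccc(C)cc1)Nc1nc2ccccc2s1`, gives 21100 nM
compound 2, `CCOc1ccc2nc(N/C(=C\C(=O)c3ccc(C)cc3)SC)sc2c1`, gives "not active" (no number reported)
compound 3, `CS/C(=C/C(=O)c1ccc(Br)cc1)Nc1nc2cc(C)c(C)cc2s1`, gives "not active" (no number reported)

In this assay, going by the values given here, compound 1 stands alone as the one compound of the three with a number, and that number marks it as a weak inhibitor. Compound 2 and compound 3 each come back without a number; the report for them says only that they were not active. Compound 4, `CS/C(=C/C(=O)c1ccc(F)cc1)Nc1nc2ccccc2s1`, differs from compound 1 in one place: fluoro in place of methyl on an aromatic carbon. Among the compounds with values here, no pair of measured compounds shows this change, so the expectation rests on compound 1 alone, with the two numberless compounds as a warning that this series readily falls out of the measurable range. The step is expected to be small, none beyond the scatter or leaning toward a weaker result, with a real chance that compound 4 again gives no number; the expected step is a 1.4-fold higher number from compound 1 to compound 4 (0.15 log units; within the scatter). Compound 4 is expected to give about 30000 nM, within a likely range from 8000 nM to 120000 nM.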

Compound 4, half-maximal inhibitory concentration: "not active" (no number reported)
Nothing numeric was reported for compound 4; there is nothing to compare the estimate with.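

Compound 4 gives no number in this assay, and the step from compound 1 to compound 4 cannot be read. The compounds shown leave open whether going from 4-methylphenyl to 4-fluorophenyl changes inhibition at all. No evidence at hand bears on this result.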